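A few compounds are considered here, and "the series" means these few. Any claim that something is new, unique, unknown or untested is made for them only; others in the source may bear on it.

Measured compounds in a functional assay on CHO cells for positive allosteric modulation of metabotropic glutamate receptor 2 (Homo sapiens), with a stated time of 30 min; on this read-out lower numbers stand for smaller maximal responses and higher numbers for larger maximal responses:

compound 1, `CC(C)CCn1ccc(N2CCc3ccccc3C2)c(C#N)c1=O`: 310%
compound 2, `CC(C)CCn1ccc(N2CCC(c3ccccc3)CC2)c(C#N)c1=O`: 268%
compound 3, `CC(C)CCn1ccc(N2CCCCC2)c(C#N)c1=O`: 185%

Compound 2 gives the second highest of the three numbers. Its nearest neighbour is compound 1, which gives 310%, a number beyond the scatter above compound 2. Its furthest neighbour is compound 3, and the only single-place step shown, a number 83 percentage points lower from compound 2 to compound 3 (beyond the scatter), is large; it replaces phenyl by hydrogen on a saturated ring carbon.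

Compound 4, `N#Cc1c(N2CCC(c3ccccc3)CC2)ccn(CCCC(F)(F)F)c1=O`, is not yet measured. Its difference from compound 2 is 2,2,2-trifluoroethyl in place of isopropyl on a saturated chain carbon, two bonds along the chain from an aromatic nitrogen. Within the data shown here, the step from compound 2 to compound 3 changes the saturated ring and so does not bear on this change; the chain on the aromatic nitrogen is the same isopentyl in compound 1, compound 2 and compound 3, so no measured step shows what altering it does in this assay . Among the measured compounds shown here, the one step that does exist, from compound 2 to compound 3, speaks only for the phenyl on the saturated ring, which compound 4 keeps.

For the measured compounds named here, with no step on the chain available, the expectation for compound 4 is a change of a number 8 percentage points lower from compound 2 to compound 4 (within the scatter), that is, none beyond the scatter. Compound 4 is therefore estimated at 260%, with a range of 190% to 320% in this assay .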

Compound 4, largest response reached (Emax), in percent of the reference or control that the assay uses: 302%
Beside the measured number, compound 4's estimate is 42 percentage points below it; measured number inside the range.
By their numbers in this assay, from the lowest: compound 3; then compound 2; then compounds 4 and 1 (each within the scatter of the next).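

With the phenyl on the saturated ring kept, the chain on the aromatic nitrogen turns out to matter in this assay: 2,2,2-trifluoroethyl in place of isopropyl gives a number 34 percentage points higher from compound 2 to compound 4 (beyond the scatter), a large step. Compound 1, compound 2 and compound 3 all carry the same isopentyl chain, so this is the first reading at this position, and it shows that the maximal response can be moved from the chain end as well as from the saturated ring, where the listed change gives a number 83 percentage points lower from compound 2 to compound 3 (beyond the scatter). Nothing available explains the rise or ties it to any property of either group.

Still open, on these data alone, is whether the rise goes with the fluorine atoms or with the change from a branched to an unbranched chain end, which a plain butyl chain would help to separate, and whether a longer chain such as 5,5,5-trifluoropentyl or a chain ending in a hydroxyl group keeps it. Also open, as far as these compounds go, is whether the same change on the chain gives a similar step on the core of compound 1 or compound 3.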